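Working notes on a biaryl series in a modulation assay

This account rests on a few compounds, and the source may have more. Where it says the series, first, only, none or still open, it means among the compounds named here.

Within the data shown here, compound 1, `Cn1sc2cc(OCc3cccc(-c4ccc(Cl)c(C(=O)O)c4)c3)ccc2c1=O`, is the only member with a number: in an assay on HEK293 cells for positive allosteric modulation of metabotropic glutamate receptor 2 (Rattus norvegicus), read by thallium flux (a higher number here means a larger maximal response, a lower number a smaller maximal response), compound 1 gives 74.7%. Compound 2, `O=C1c2ccc(OCc3cccc(-c4ccccc4)c3)cc2CN1C1CCCC1`, carries a different core; in this assay compound 2 gives "not determined" (no result reported), so no number stands for compound 2 and nothing can be said about where it lies relative to compound 1. Compound 3, `O=C(O)c1ccc(-c2cccc(COc3ccc4c(c3)CN(C3CCCC3)C4=O)c2)c(Cl)c1`, keeps the core of compound 2 and alters one ring: 4-carboxy-2-chlorophenyl in place of phenyl on an aromatic carbon. A 4-carboxy-2-chlorophenyl thus takes the place of phenyl on an aromatic carbon, meta to a large group. Among the measured compounds shown here, no measured pair shows this step, and the only carboxy-bearing compound with a value, compound 1, has another core and another arrangement of carboxy and chlorine on its ring, so the size of the step cannot be read from the data; a move beyond the scatter in either direction is possible, and none beyond it is equally possible. Compound 1 gives 74.7% in this assay and is the sole anchor. Compound 3 is therefore expected near 70%, with a range from 40% to 100%.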

Compound 3, largest response reached (reported as percent of maximum), in percent of the reference or control that the assay uses: 89.4%
Estimate against measurement, compound 3: 19.4 percentage points below; low and high end bracket the measured number.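

No step can be read from the result for compound 3: compound 2 has no number in this assay and compound 1 differs from compound 3 in more than one place. From the compounds shown here alone, what 4-carboxy-2-chlorophenyl in place of phenyl does to the response on the core of compound 2 stays open. No evidence bears on this result.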